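Swapping the methylsulfanyl group for trifluoromethyl on compound 2

The compounds below may be only part of what the source reports. "The series", "measured", "known", "first", "only" and "open" are said of these compounds alone.

Three ureas sharing one core have been tested. Compound 1 `O=C(Nc1cccc(F)c1)N[C@H]1CC[C@H](Oc2ccc(F)cc2)CC1` carries a 3-fluorophenyl on the urea nitrogen and gives 8300 nM in a functional assay on CRL2813 cells (Homo sapiens) for cytotoxicity, read by sulforhodamine B assay, with a stated time of 5 days; a higher number here means a weaker inhibitor, a lower number a stronger inhibitor. Compound 3 `O=C(Nc1cccc([N+](=O)[O-])c1)N[C@H]1CC[C@H](Oc2ccc(F)cc2)CC1` carries a 3-nitrophenyl instead and gives 6700 nM in this assay, a difference of a 1.2-fold lower number from compound 1 to compound 3 (0.09 log units; within the scatter). Compound 2 `CSc1ccccc1NC(=O)N[C@H]1CC[C@H](Oc2ccc(F)cc2)CC1` carries a 2-(methylsulfanyl)phenyl and reaches only the limit of this assay, > 20000 nM, so for compound 2 no number is known, only that it sits at the top (the limit of > 20000 nM in this assay, at which 1 of the 3 values shown sits). The steps from the other two compounds to it are an at least 2.4-fold higher number from compound 1 to compound 2 (0.38 log units; beyond the scatter) and, read the other way, an at least 2.9-fold lower number from compound 2 to compound 3 (0.47 log units; beyond the scatter), so compound 2 is the weakest of the three shown.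

Compound 4 `O=C(Nc1ccccc1C(F)(F)F)N[C@H]1CC[C@H](Oc2ccc(F)cc2)CC1` differs from compound 2 in one place: trifluoromethyl in place of methylsulfanyl on an aromatic carbon. No measured step changes the group on this aromatic carbon ortho to a large group, so nothing shown bears directly on this exchange; the only hint is that the one compound with a group at that place, compound 2, is weak. Compound 4 is therefore expected to stay near the limit as well, a step of about an at least 1.1-fold lower number from compound 2 to compound 4 (0.04 log units; that floor lies within the scatter). The estimate for compound 4 is 18000 nM, within a range from 6000 nM to 50000 nM.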

Compound 4, half-maximal inhibitory concentration: > 20000 nM
Compound 4 was reported as a limit; the forecaster's own chance of this, stated with the estimate: 50%; at least 1.1-fold (0.04 log units) between middle value and limit.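

Compound 2 and compound 4 both stop at the limit of this assay, so no step can be read for trifluoromethyl in place of methylsulfanyl: the limit of > 20000 nM in this assay, at which 2 of the 4 values shown sit.

The compounds shown leave open how weak compound 2 and compound 4 really are, and whether the two groups differ at all on this aromatic carbon.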